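Sulfonamide heteroaryl swaps in one growth-inhibition series

A few compounds are considered here, and "the series" means these few. Any claim that something is new, unique, unknown or untested is made for them only; others in the source may bear on it.

Measured compounds, with their numbers in a functional assay on PC-3 cells (Homo sapiens) for inhibition, read by sulforhodamine B assay, with a stated time of 48 h; on this read-out lower numbers stand for stronger inhibition of growth and higher numbers for weaker inhibition of growth:
compound 1 `C=C1CC[C@@H]2[C@](C)(COC(C)=O)[C@H](OC(C)=O)CC[C@@]2(C)[C@H]1CC(Nc1ccc(S(=O)(=O)Nc2ccc(Cl)nn2)cc1)C1=CCOC1=O` gives 2240 nM
compound 2 `C=C1CC[C@@H]2[C@](C)(COC(C)=O)[C@H](OC(C)=O)CC[C@@]2(C)[C@H]1CC(Nc1ccc(S(=O)(=O)Nc2nccc(C)n2)cc1)C1=CCOC1=O` gives 4460 nM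
compound 3 `C=C1CC[C@@H]2[C@](C)(COC(C)=O)[C@H](OC(C)=O)CC[C@@]2(C)[C@H]1CC(Nc1ccc(S(=O)(=O)Nc2ncccn2)cc1)C1=CCOC1=O` gives 2110 nM

Compound 1 stands second highest of the three numbers; compound 3 is nearest to it, and compound 2 is furthest, both within the scatter of it. The three differ only in the ring on the sulfonamide nitrogen.

Compound 4 `C=C1CC[C@@H]2[C@](C)(COC(C)=O)[C@H](OC(C)=O)CC[C@@]2(C)[C@H]1CC(Nc1ccc(S(=O)(=O)Nc2nccs2)cc1)C1=CCOC1=O` is the next member. It differs from compound 1 in one place: 1,3-thiazol-2-yl in place of 6-chloropyridazin-3-yl on a sulfonamide nitrogen.

Within the data shown here, two measured steps bear on this kind of change, each a swap of the ring on the sulfonamide nitrogen of compound 1: a 2.0-fold higher number from compound 1 to compound 2 (0.30 log units; within the scatter) and a 1.1-fold lower number from compound 1 to compound 3 (0.03 log units; within the scatter). Neither moves the number beyond the scatter. Among the measured compounds shown here, the only step that reaches beyond the scatter is a 2.1-fold lower number from compound 2 to compound 3 (0.33 log units; beyond the scatter), a change of a methyl on one of those rings, which does not apply here. With a third ring of the same kind entering in this assay , no step beyond the scatter is expected in either direction: compound 4 is estimated to give 2500 nM, within 1000 nM to 6500 nM, and the expected step is a 1.1-fold higher number from compound 1 to compound 4 (0.05 log units; within the scatter).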

Compound 4, concentration for 50% growth inhibition: 7740 nM
For compound 4 the middle estimate is 3.1-fold (0.49 log units) below the measured one; measured number above the stated range.
By their numbers in this assay, from the lowest: compounds 3, 1, 2 and 4 (each within the scatter of the next, the first and the last beyond it).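

In this assay, the ring on the sulfonamide nitrogen can move the number beyond the scatter when the starting point is compound 1: 1,3-thiazol-2-yl in place of 6-chloropyridazin-3-yl gives a 3.5-fold higher number from compound 1 to compound 4 (0.54 log units; beyond the scatter), and in place of pyrimidin-2-yl it gives a 3.7-fold higher number from compound 3 to compound 4 (0.56 log units; beyond the scatter). The change is not beyond the scatter against every ring, since 1,3-thiazol-2-yl in place of 4-methylpyrimidin-2-yl gives a 1.7-fold higher number from compound 2 to compound 4 (0.24 log units; within the scatter), so this position separates compounds 1 and 3 from compound 4 while compound 2 stays within the scatter of compound 4. Nothing available explains the shift.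

Among these compounds, compound 4 is the only member here with a five-membered aromatic ring and the only one with sulfur in that ring, so the two features cannot be told apart; an oxazolyl ring or a thienyl ring on the same sulfonamide nitrogen would help to separate them. Also open, from the compounds shown here alone, is how a plain phenyl ring at this place would compare with the heteroaryl rings, and whether the same steps appear outside this assay.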